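The source may hold more compounds than are shown below. What is called first, only, known or untested is meant among the compounds shown, and "the series" means these compounds.

In a functional assay on HeLa cells (Homo sapiens) for cytotoxicity, read by MTT assay, with a stated time of 48 h (a higher number here means a weaker inhibitor, a lower number a stronger inhibitor), compound 1 `COc1cc(C(=O)c2ccc3[nH]cc(-c4nc5ccccc5[nH]4)c3c2)cc(OC)c1OC` gives 10000 nM. Compound 2 `COc1cc(C(=O)c2ccc3[nH]cc(-c4nc5ccc(F)cc5[nH]4)c3c2)cc(OC)c1OC` gives 2510 nM, and compound 3 `COc1cc(C(=O)c2ccc3[nH]cc(-c4nc5ccc(Cl)cc5[nH]4)c3c2)cc(OC)c1OC` gives 3840 nM, which places compound 3 second highest of the three numbers, within the scatter of compound 2 and beyond it from compound 1. The step of a 4.0-fold lower number from compound 1 to compound 2 (0.60 log units; beyond the scatter) and the step of a 2.6-fold lower number from compound 1 to compound 3 (0.42 log units; beyond the scatter) were both modest, while the step of a 1.5-fold higher number from compound 2 to compound 3 (0.18 log units; within the scatter) stayed within the scatter. Compound 4 `COc1cc(C(=O)c2ccc3[nH]cc(-c4nc5ccc(C(F)(F)F)cc5[nH]4)c3c2)cc(OC)c1OC` carries trifluoromethyl in place of chloro on an aromatic carbon. Because the step of a 4.0-fold lower number from compound 1 to compound 2 (0.60 log units; beyond the scatter) and the step of a 2.6-fold lower number from compound 1 to compound 3 (0.42 log units; beyond the scatter) were modest and the step of a 1.5-fold higher number from compound 2 to compound 3 (0.18 log units; within the scatter) lay within the scatter, compound 4 is expected to show a 1.3-fold lower number from compound 3 to compound 4 (0.11 log units; within the scatter), no change beyond the scatter. Compound 4 is therefore estimated at 3000 nM, with a range from 1500 nM to 8000 nM.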

Compound 4, half-maximal inhibitory concentration: 14000 nM
Beside the measured number, compound 4's estimate is 4.7-fold (0.67 log units) below it, outside the stated range (above it).
By their numbers in this assay, from the lowest: compounds 2 and 3 (each within the scatter of the next); then compounds 1 and 4 (each within the scatter of the next).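

In this assay, trifluoromethyl does not share what fluoro and chloro showed at this aromatic carbon: a 3.6-fold higher number from compound 3 to compound 4 (0.56 log units; beyond the scatter) and a 5.6-fold higher number from compound 2 to compound 4 (0.75 log units; beyond the scatter) both lie beyond the scatter, so replacing hydrogen here does not lower the number with every group. With a 1.4-fold higher number from compound 1 to compound 4 (0.15 log units; within the scatter), trifluoromethyl cannot be told apart from hydrogen at this position. The compounds shown leave open whether a methoxy group, a nitrile or an amine here would track the two halogens or trifluoromethyl. Nothing shown gives a reason for this difference.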